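Replacing 3-chlorophenyl with benzyl on a purine-type scaffold

The source may hold more compounds than are shown below. What is called first, only, known or untested is meant among the compounds shown, and "the series" means these compounds.

Three compounds share a scaffold that carries an aminobenzamide-type side arm and have been compared in a functional assay on HepG2 cells (Homo sapiens) for antiproliferative activity, read by CCK-8 assay, with a stated time of 72 h, tested at 8 uM; on this read-out higher numbers stand for a stronger effect at the one concentration tested and lower numbers for a weaker effect. Compound 1 `Cc1ccc(Nc2nc(Cl)nc3c2ncn3Cc2ccc(C(=O)Nc3ccccc3N)cc2)cc1` gives 82% in this assay, compound 3 `Nc1ccccc1NC(=O)c1ccc(COCNc2nc(Nc3cccc(Cl)c3)c3ncn(C4CCCC4)c3n2)cc1` gives 63.2%, and compound 2 `Nc1ccccc1NC(=O)/C=C/c1ccc(Cn2cnc3c(Nc4cccc(Cl)c4)nc(Cl)nc32)cc1` gives 49.3%. On these numbers compound 2 stands lowest of the three: its gap to compound 3 is beyond the scatter, and its gap to compound 1 is wider still and also beyond the scatter.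

Compound 4 `Nc1ccccc1NC(=O)/C=C/c1ccc(Cn2cnc3c(NCc4ccccc4)nc(Cl)nc32)cc1` has not yet been measured. It differs from compound 2 in one place: benzyl in place of 3-chlorophenyl on a nitrogen on an aromatic ring. Both groups have the same count of heavy atoms and one six-membered aromatic ring, neither adds a donor or an acceptor, and the change is read as (3-chlorophenyl)amino to benzylamino.

Within the data shown here, no measured pair isolates this exact change, so the expectation rests on compound 2 alone. A small step, most likely not beyond the scatter, is expected from compound 2 to compound 4 a number 4.3 percentage points lower from compound 2 to compound 4 (within the scatter). Compound 4 is therefore estimated at 45%, within a range of 25% to 65%.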

Compound 4, a percentage reported as inhibition, at one concentration (the size of the read-out at that concentration, not a potency): 37.7%
Estimate against measurement, compound 4: 7.3 percentage points above, within the range that was stated.
By their numbers in this assay, from the lowest: compound 4; then compound 2; then compound 3; then compound 1.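

In this assay the pair of compounds that differ in one place gives this position its first measured step: a number 11.6 percentage points lower from compound 2 to compound 4 (beyond the scatter). Among these compounds, the group on the nitrogen on an aromatic ring therefore bears on the read-out, which the earlier compounds, differing in more than one place, could not show. Benzyl and 3-chlorophenyl have the same count of heavy atoms and one six-membered aromatic ring each, so the number moved with those counts unchanged, and no measurement at hand speaks to what lies behind the step.

The pair leaves open whether the step follows the loss of chlorine or the added carbon between ring and nitrogen, which a plain phenyl on the same nitrogen would help to separate. On these data alone, how a longer chain such as 2-phenylethyl would read at this position also stays open.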